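Opening a bicyclic amine into a chain

The source may report more compounds than this note shows. Statements on the series, on what has been measured and on what is new or still open speak of the compounds shown alone.

Compound 2 `COc1cc(C)c(S(=O)(=O)N(C)CCOCC(=O)N2CCN([C@@H]3CN4CCC3CC4)CC2)c(C)c1` shows the highest of the two numbers in an assay on HEK293 cells for displacement of a labelled ligand from B1 bradykinin receptor (Homo sapiens), read by scintillation counting (a higher number here means a weaker inhibitor, a lower number a stronger inhibitor), where compound 2 gives 5.6 nM. Compound 1 `COc1cc(C)c(S(=O)(=O)N(C)CCOCC(=O)N2CCN(C3CCN(C4CC4)CC3)CC2)c(C)c1` gives 0.8 nM in this assay. Among the measured compounds shown here, the single measured step, a 7.0-fold higher number from compound 1 to compound 2 (0.85 log units; beyond the scatter), concerns a group on the same ring nitrogen. Compound 3 `COc1cc(C)c(S(=O)(=O)N(C)CCOCC(=O)N2CCN(CCCN(C)C)CC2)c(C)c1` differs from compound 2 by a group of 6 heavy atoms (5 carbon, 1 nitrogen; no ring) in place of a group of 8 heavy atoms (7 carbon, 1 nitrogen; 2 six-membered non-aromatic rings with 1 hetero atom each), on an amine nitrogen in a ring. That earlier step offers no close parallel to opening the rings into a chain, so a step near a 1.8-fold higher number from compound 2 to compound 3 (0.25 log units; within the scatter) is expected with wide uncertainty. Compound 3 is therefore estimated at 10 nM in this assay, ranging from 2 nM to 50 nM.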

Compound 3, inhibition constant: 5.8 nM
Compound 3: middle estimate off by 1.7-fold (0.24 log units), on the high side; the range from low to high includes it.
By their numbers in this assay, from the lowest: compound 1; then compounds 2 and 3 (each within the scatter of the next).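

In this assay, the open 3-(dimethylamino)propyl chain gives a 1.0-fold higher number from compound 2 to compound 3 (0.02 log units; within the scatter) on the amine nitrogen in a ring, so the two-ring group and this chain cannot be told apart at this position. The 1-cyclopropylpiperidin-4-yl group stays ahead of the chain, with a 7.3-fold higher number from compound 1 to compound 3 (0.86 log units; beyond the scatter) beyond the scatter. Nothing available explains either step. The compounds shown leave open whether a longer chain or a shorter one would do the same. They also leave open whether a chain ending in a pyrrolidine instead of the dimethylamine would close the gap to compound 1.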